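Series notes: aryl swap on the five-membered ring

This account rests on a few compounds, and the source may have more. Where it says the series, first, only, none or still open, it means among the compounds named here.

Measured so far in an assay on Sf9 cells for inhibition of protein deacetylase HDAC6 (Homo sapiens), read by fluorescence, with a stated time of 40 min, tested at 100 nM; on this read-out higher numbers stand for more inhibition at the one concentration tested (going by the name of the read-out) and lower numbers for less inhibition:
compound 1, `COc1ccc(-n2nc(-c3ccccc3)nc2CNc2ccc(C(=O)NO)cc2)cc1`, 63.4%
compound 2, `O=C(NO)c1ccc(NCc2nc(-c3cccc4cnccc34)nn2-c2ccccc2)cc1`, 40.2%
compound 3, `O=C(NO)c1ccc(NCc2nc(-c3ccccc3)nn2-c2cccc(Cl)c2)cc1`, 62.3%

Compound 2 stands lowest of the three in this assay; compound 3 and compound 1 both lie beyond the scatter above it, and the two of them sit within the scatter of each other. Among the measured compounds shown here, the one measured step, a number 1.1 percentage points lower from compound 1 to compound 3 (within the scatter), concerns the aryl group on the aromatic nitrogen and is within the scatter.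

Compound 4, `O=C(NO)c1ccc(NCc2nc(-c3ccc(F)cc3)nn2-c2ccccc2)cc1`, is not yet measured. Its change from compound 2 is 4-fluorophenyl in place of isoquinolin-5-yl on an aromatic carbon. For the measured compounds named here, no measured step touches this position. What the values show is that compound 1 and compound 3, each carrying a phenyl group on that aromatic carbon, give the two higher numbers, while compound 2 with isoquinolin-5-yl gives the lowest. On that basis a rise beyond the scatter is expected from compound 2 to compound 4, the estimated step being a number 19.8 percentage points higher from compound 2 to compound 4 (beyond the scatter), toward the level of the phenyl-bearing pair. For compound 4 the expected inhibition in this assay is 60%, with a range from 45% to 75%.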

Compound 4, a percentage reported as inhibition, at one concentration (the size of the read-out at that concentration, not a potency): 70.9%
Compound 4: middle estimate off by 10.9 percentage points, on the low side, and the stated range covers the measured number.
By their numbers in this assay, from the lowest: compound 2; then compounds 3, 1 and 4 (each within the scatter of the next).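

The position on the aromatic carbon between two ring nitrogen atoms now has its first measured step: in this assay, 4-fluorophenyl in place of isoquinolin-5-yl gives a number 30.7 percentage points higher from compound 2 to compound 4 (beyond the scatter). Among the compounds shown here, this position therefore responds to the aryl group it carries, whereas the only earlier step, at the aromatic nitrogen, was a number 1.1 percentage points lower from compound 1 to compound 3 (within the scatter). The change is a composite one, since the 10 heavy atoms of isoquinolin-5-yl, including its ring nitrogen and hydrogen-bond acceptor, give way to the 7 heavy atoms of 4-fluorophenyl, and nothing available explains the rise or assigns it to one of these differences.

Open, as far as these compounds go, is whether a naphthalen-1-yl group on this carbon, which has the carbon skeleton of a fused pair of rings with no ring nitrogen, would read with compound 2 or with compound 4. Also open, from the compounds shown here alone, is what the fluorine contributes on its own, which an unsubstituted phenyl group at this position in the same compound, or a 4-aminophenyl or 4-carboxyphenyl group there, would begin to separate from the loss of isoquinolin-5-yl.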